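Amide nitrogen variation on the shared core, stability notes

The source may hold more compounds than are shown below. What is called first, only, known or untested is meant among the compounds shown, and "the series" means these compounds.

The series shares one core, seen in compound 1 `COC(=O)c1cc(N)c(Nc2ccc(C#N)cc2)cc1Oc1c(C)cc(/C=C/C#N)cc1C` and compound 2 `Cc1cc(/C=C/C#N)cc(C)c1Oc1cc(Nc2ccc(C#N)cc2)c(N)cc1C(=O)NN`. In an ADME assay on microsomes from liver (Homo sapiens) for metabolic stability, read by LC-MS, using NADPH, with a stated time of 45 min, tested at 1 uM (a higher number here means that the compound lasts longer, a lower number that the compound disappears faster), compound 1 gives 0.308 h, and compound 2 gives 0.6 h; the two lie within the scatter of each other, a 1.9-fold higher number from compound 1 to compound 2 (0.29 log units; within the scatter). Compound 3 `CNC(=O)c1cc(N)c(Nc2ccc(C#N)cc2)cc1Oc1c(C)cc(/C=C/C#N)cc1C` differs from compound 2 by methyl in place of amino on an amide-type nitrogen. Among the measured compounds shown here, the only measured step changed the same group on the carbonyl carbon and stayed within the scatter, so for compound 3 no step beyond the scatter is expected in this assay, a 1.3-fold lower number from compound 2 to compound 3 (0.12 log units; within the scatter). Compound 3 is therefore estimated at 0.45 h, with a range from 0.2 h to 1 h.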

Compound 3, half-life in the liver assay: 1.87 h
The estimate for compound 3 lay 4.2-fold (0.62 log units) below the measured number, outside the stated range (above it).
By their numbers in the liver assay, from the lowest: compounds 1 and 2 (each within the scatter of the next); then compound 3.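

In the liver assay, the methyl on the amide-type nitrogen gives steps beyond the scatter, a 3.1-fold higher number from compound 2 to compound 3 (0.49 log units; beyond the scatter) and a 6.1-fold higher number from compound 1 to compound 3 (0.78 log units; beyond the scatter), whereas the earlier change on the carbonyl carbon stayed within it. In a physicochemical assay for solubility, read by HPLC, in phosphate buffer, with a stated time of 4 h, at pH 7.4 (a lower number here means a less soluble compound, a higher number a more soluble compound), compound 2 gives 2.4 ug/mL and compound 3 gives 8.28 ug/mL, a 3.5-fold higher number from compound 2 to compound 3 (0.54 log units; beyond the scatter), so compound 3 has the higher number in both read-outs.

From the compounds shown here alone, whether a longer chain such as ethyl on the amide-type nitrogen, or a dimethylamide, would keep these higher numbers remains open.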